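The compounds below may be only part of what the source reports. "The series", "measured", "known", "first", "only" and "open" are said of these compounds alone.

Series notes. Three analogues share the core of compound 3 `COC(=O)/C=C/C(=O)N[C@@H](C)Cn1ccc(-c2ccc(C#N)c(Cl)c2)n1` and have been run in a functional assay on LNCaP cells (Homo sapiens) for antiproliferative activity, read by CCK-8 assay, with a stated time of 6 days; a higher number here means a weaker inhibitor, a lower number a stronger inhibitor. Compound 1 `CC(=O)c1cc(C(=O)N[C@H](C)Cn2ccc(-c3cc(F)c(C#N)c(Cl)c3)n2)n[nH]1` gives 1080 nM. Compound 2 `CC(O)c1cccc(C(=O)N[C@@H](C)Cn2ccc(-c3ccc(C#N)c(Cl)c3)n2)c1` gives 2280 nM. Compound 3 itself gives 2460 nM, the highest of the three numbers; the gap to compound 2 is within the scatter, the gap to compound 1 is beyond it. Within the data shown here, the one single-point step on record, a 1.1-fold higher number from compound 2 to compound 3 (0.03 log units; within the scatter), shows that swapping the group on the carbonyl carbon changed little.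

Compound 4 `C[C@@H](Cn1ccc(-c2ccc(C#N)c(Cl)c2)n1)Nc1ncccn1` is not yet measured. It differs from compound 3 as follows: pyrimidin-2-yl in place of (2-(methoxycarbonyl)ethenyl)carbonyl on an amine nitrogen. Among the measured compounds shown here, no measured step touches the amine nitrogen in this way; the only step on record concerns the carbonyl side and was flat, so it bears only loosely here. With the carbonyl gone altogether, a step of any size in either direction cannot be ruled out, and nothing in the data points one way. The expectation is therefore a number near that of compound 3, with a wide range: compound 4 is estimated at 2000 nM (range 600 nM to 7000 nM), a step of a 1.2-fold lower number from compound 3 to compound 4 (0.09 log units; within the scatter) expected.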

Compound 4, half-maximal inhibitory concentration: 1180 nM
The estimate for compound 4 lay 1.7-fold (0.23 log units) above the measured number; low and high end bracket the measured number.
By their numbers in this assay, from the lowest: compounds 1, 4, 2 and 3 (each within the scatter of the next, the first and the last beyond it).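

In this assay, the amine nitrogen accepts the complete loss of the carbonyl without a loss of activity: pyrimidin-2-yl in place of (2-(methoxycarbonyl)ethenyl)carbonyl gives a step beyond the scatter (a 2.1-fold lower number from compound 3 to compound 4 (0.32 log units; beyond the scatter)). Among these compounds, the earlier step on the carbonyl carbon was flat (a 1.1-fold higher number from compound 2 to compound 3 (0.03 log units; within the scatter)), so this is the only single-place change on record that moves the number beyond the scatter, and it shows that an acyl group on this nitrogen is not needed for activity at this level. No measurement on hand gives a reason for this step.

As far as these compounds go, it remains open whether the step belongs to the aromatic ring or to the removal of the acyl group. A phenyl group, a pyridin-2-yl group or a plain methyl group on the same amine nitrogen would separate these two readings.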